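Aryl swap on the saturated ring carbon: lipophilicity notes

A few compounds are considered here, and "the series" means these few. Any claim that something is new, unique, unknown or untested is made for them only; others in the source may bear on it.

Of the compounds shown here, two have been measured in a physicochemical assay for lipophilicity; a higher number here means a more lipophilic compound, a lower number a more polar compound. Compound 1 `C[C@H]1CC[C@@H]2[C@@H](OC(=O)[C@]23CC(c2ccc(Cl)cc2)=NO3)[C@]2(C)C(=O)C=C[C@@]12O` gives 2.09. Compound 2 `C[C@H]1CC[C@@H]2[C@@H](OC(=O)[C@]23CC(c2ccc(C#N)cc2)N(c2ccccc2)O3)[C@]2(C)C(=O)C=C[C@@]12O` gives 2.94, the higher of the two numbers, with compound 1 lying below it by more than the usual scatter. Compound 3 `COc1cccc(C2C[C@@]3(ON2c2ccccc2)C(=O)O[C@@H]2[C@H]3CC[C@H](C)[C@]3(O)C=CC(=O)[C@@]23C)c1` has not yet been measured; it differs from compound 2 in one place: 3-methoxyphenyl in place of 4-cyanophenyl on a saturated ring carbon. Among the measured compounds shown here, no step between measured compounds differing in a single place is available, so the expectation rests on compound 2 alone. The step of a number 0.46 log units higher from compound 2 to compound 3 (beyond the scatter) is expected to be upward and modest, somewhat beyond the scatter. Compound 3 is estimated at 3.4, within a range from 3 to 3.9.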

Compound 3, partition coefficient: 3.25
For compound 3 the middle estimate is 0.15 log units above the measured one; measured number inside the range.
By their numbers in this assay, from the lowest: compound 1; then compound 2; then compound 3.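

In this assay, the saturated ring carbon now has its first measured single-place change: 3-methoxyphenyl in place of 4-cyanophenyl gives a number 0.31 log units higher from compound 2 to compound 3 (beyond the scatter), a modest step. This position therefore responds to an aryl swap even with equal heavy-atom, hydrogen-bond donor and acceptor counts in the two groups. No measurement bears on the cause of this step.

One step cannot show whether the shift follows the methoxy group, the loss of the nitrile or the different attachment pattern on the phenyl ring. As far as these compounds go, how an aminomethyl group or a carboxylic acid on this carbon would read in this assay remains open.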